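Furan-2-yl in Place of Thiophen-3-yl: Expecting Compound 4

This account rests on a few compounds, and the source may have more. Where it says the series, first, only, none or still open, it means among the compounds named here.

Compound 1 `Oc1ccc(-c2cc(-c3ccccc3)cc(-c3ccsc3)n2)cc1` and compound 2 `Oc1ccc(-c2cc(-c3ccccc3)cc(-c3ccco3)n2)cc1` share one core, while compound 3 `Oc1cccc(-c2cc(-c3ccccc3)nc(-c3ccsc3)c2)c1` is built from the same atoms joined differently; the difference between the two cores is not broken down here. In a functional assay on HL-60 cells (Homo sapiens) for cytotoxicity, read by ELISA, with a stated time of 2 days (a higher number here means a weaker inhibitor, a lower number a stronger inhibitor), compound 1 gives 3600 nM and compound 2 gives 3300 nM, so the change furan-2-yl in place of thiophen-3-yl on an aromatic carbon made a 1.1-fold lower number from compound 1 to compound 2 (0.04 log units; within the scatter). In this assay compound 3 gives 12000 nM. Compound 4 `Oc1cccc(-c2cc(-c3ccccc3)nc(-c3ccco3)c2)c1` is the unmeasured partner of compound 3 and differs from it by furan-2-yl in place of thiophen-3-yl on an aromatic carbon. This is the same kind of change as from compound 1 to compound 2, though here the place is meta to a 3-hydroxyphenyl group rather than meta to a 4-hydroxyphenyl group. Because a 1.1-fold lower number from compound 1 to compound 2 (0.04 log units; within the scatter), a step of similar size is expected here: a 1.1-fold lower number from compound 3 to compound 4 (0.04 log units; within the scatter). Compound 4 is therefore estimated at 11000 nM, most likely between 5000 nM and 25000 nM in this assay.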

Compound 4, half-maximal inhibitory concentration: 24000 nM
Estimate against measurement, compound 4: 2.2-fold (0.34 log units) below; the measured number falls inside the stated range.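

In this assay, furan-2-yl in place of thiophen-3-yl gave a 2.0-fold higher number from compound 3 to compound 4 (0.30 log units; within the scatter), a step as small as the scatter of repeated measurements. Set beside the earlier step, it shows no real difference between the two cores: the same change on two cores in this assay, a 1.1-fold lower number (0.04 log units; within the scatter) from compound 1 to compound 2 and a 2.0-fold higher number (0.30 log units; within the scatter) from compound 3 to compound 4, 2.2-fold (0.34 log units) apart, within the scatter of two such steps. The change therefore behaved alike on these two cores, with neither step standing out from the scatter, but two pairs in one assay do not show that it would do so on any other core.

Still open, going by these compounds, is what a quite different group at this place, such as an amine or a carboxylic acid, would do to the number.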